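Trimming the amine tail of a dialkylated aminoglycoside core

This account rests on a few compounds, and the source may have more. Where it says the series, first, only, none or still open, it means among the compounds named here.

Measured compounds:
compound 1 `CCCCCCCCCO[C@@H]1[C@@H](N)[C@@H](OCC(O)CO)O[C@H](CN)[C@H]1OCCCCCCCCC` gives 8.8%
compound 2 `CCCCCCCCCO[C@@H]1[C@@H](N)[C@@H](OCC(O)CNCCO)O[C@H](CN)[C@H]1OCCCCCCCCC` gives 10.1%
compound 3 `CCCCCCCCCO[C@@H]1[C@@H](N)[C@@H](OCC(O)CNCCN)O[C@H](CN)[C@H]1OCCCCCCCCC` gives 53%

In a toxicity assay on the whole organism (J774 cells) for cytotoxicity, with Mus musculus as the target, read by MTT assay, with a stated time of 24 h, tested at 30 uM (on this read-out higher numbers stand for a weaker effect at the one concentration tested and lower numbers for a stronger effect), compound 3 stands highest of the three, beyond the scatter from both compound 2 and compound 1. The steps that lead there are uneven: a number 1.3 percentage points higher from compound 1 to compound 2 (within the scatter), whereas a number 44.2 percentage points higher from compound 1 to compound 3 (beyond the scatter) and a number 42.9 percentage points higher from compound 2 to compound 3 (beyond the scatter). Going by the values given here, the one change that ends in a terminal amine, amino in place of hydroxy on a saturated chain carbon two bonds along from an amine nitrogen, is thus the large one.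

Compound 4 `CCCCCCCCCO[C@@H]1[C@@H](N)[C@@H](OC[C@@H](O)CN)O[C@H](CN)[C@H]1OCCCCCCCCC` is not yet measured. It differs from compound 3 as follows: 2-amino-1-hydroxyethyl in place of 2-((2-aminoethyl)amino)-1-hydroxyethyl on a saturated chain carbon bound to an oxygen on a saturated carbon The chain is cut back to one amine, so compound 4 carries a terminal amino group like compound 3 but on a shorter arm, and is also compound 1 with amino in place of its terminal hydroxy. Among the compounds with values here, no measured step covers shortening the arm. Because a number 42.9 percentage points higher from compound 2 to compound 3 (beyond the scatter) was large, compound 4 is expected to lie well above compound 1, and a step of a number 13 percentage points lower from compound 3 to compound 4 (beyond the scatter) is estimated. Compound 4 is therefore estimated at 40%, within 15% to 65%.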

Compound 4, a percentage reported as activity, at one concentration (the size of the read-out at that concentration, not a potency): 7.2%
Beside the measured number, compound 4's estimate is 32.8 percentage points above it, and the stated range ends above it.
By their numbers in this assay, from the lowest: compounds 4, 1 and 2 (each within the scatter of the next); then compound 3.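

In this assay, a terminal amino group on the short arm does not by itself raise the number: 2-amino-1-hydroxyethyl in place of 1,2-dihydroxyethyl gives a number 1.6 percentage points lower from compound 1 to compound 4 (within the scatter), and in place of 1-hydroxy-2-((2-hydroxyethyl)amino)ethyl it gives a number 2.9 percentage points lower from compound 2 to compound 4 (within the scatter). Only cutting back the 2-((2-aminoethyl)amino)-1-hydroxyethyl arm moves the number, with a number 45.8 percentage points lower from compound 3 to compound 4 (beyond the scatter). Among these four compounds, the high number therefore goes with the whole (2-aminoethyl)amino arm and not with a terminal amino group alone, which the earlier compounds could not separate.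

Nothing shown here explains this difference between the arms. On these data alone, it also remains open whether a longer (3-aminopropyl)amino arm or a terminal carboxylic acid at this position would read like compound 3 or like compound 4.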